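The source may hold more compounds than are shown below. What is called first, only, known or untested is meant among the compounds shown, and "the series" means these compounds.

In an ADME assay on microsomes from liver (Homo sapiens) for metabolic stability (a lower number here means slower removal, a higher number faster removal of the compound), three compounds with one shared core have been measured. Compound 1 `Cc1ccc2[nH]c(C(=O)N[C@H]3CN(S(=O)(=O)c4ccccc4)C[C@@H]3C(=O)NC[C@H]3CCCN3)cc2c1` gives < 3 mL.min-1.g-1, which is a limit of the assay rather than a number. Compound 2 `Cc1ccc2[nH]c(C(=O)N[C@H]3CN(S(=O)(=O)c4ccccc4)C[C@@H]3C(=O)NC[C@H]3CCCN3C)cc2c1` gives 22 mL.min-1.g-1. Compound 3 `Cc1ccc2[nH]c(C(=O)N[C@H]3CN(S(=O)(=O)c4ccccc4)C[C@@H]3C(=O)N[C@H]3CCCNC3)cc2c1` gives < 3 mL.min-1.g-1, again a limit and not a number. Compound 3 thus stands at the limit of < 3 mL.min-1.g-1 in this assay, at which 2 of the 3 values shown sit, the lowest position the numbers shown can mark. The measured steps all concern other parts of the molecule: an at least 7.3-fold higher number from compound 1 to compound 2 (0.86 log units; beyond the scatter), an at least 7.3-fold lower number from compound 2 to compound 3 (0.86 log units; beyond the scatter), while a step that the two limits leave unreadable from compound 1 to compound 3. Compound 4 `O=C(N[C@H]1CN(S(=O)(=O)c2ccccc2)C[C@@H]1C(=O)N[C@H]1CCCNC1)c1nnc(-c2ccc(F)cc2)s1` differs from compound 3 only by a group of 12 heavy atoms (8 carbon, 2 nitrogen, 1 fluorine, 1 sulfur; one five-membered aromatic ring with 3 hetero atoms, one six-membered aromatic ring of carbon only) in place of a group of 10 heavy atoms (9 carbon, 1 nitrogen; one five-membered aromatic ring with 1 hetero atom, one six-membered aromatic ring of carbon only), on a carbonyl carbon, on a carbonyl carbon whose other neighbour is an amide-type nitrogen. Within the data shown here, none of the measured steps alters this position, so none gives a direct guide to the size or direction of the change. Compound 3 sits at a limit of the assay. For compound 4 the expected step is an at least 1.3-fold higher number from compound 3 to compound 4 (0.12 log units; that floor lies within the scatter), a small rise that may stay within the scatter. The estimate for compound 4 is 4 mL.min-1.g-1, between 2 mL.min-1.g-1 and 12 mL.min-1.g-1.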

Compound 4, intrinsic clearance in microsomes: 8.8 mL.min-1.g-1
Compound 4: the middle estimate sits 2.2-fold (0.34 log units) below what was measured; measured number inside the range.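

In this assay, this is the only change shown on the carbonyl carbon whose other neighbour is the amide-type nitrogen, and it gives an at least 2.9-fold higher number from compound 3 to compound 4 (0.46 log units; beyond the scatter). With the piperidin-3-yl amide held fixed, replacing 5-methyl-1H-indol-2-yl with the new two-ring group moves the number beyond the scatter, so this position does affect the read-out. Compound 3 gives < 3 mL.min-1.g-1, which is a limit and not a number, so the full size of the step cannot be read: the limit of < 3 mL.min-1.g-1 in this assay, at which 2 of the 4 values shown sit.

Which part of the entering group matters stays open, as its five-membered ring and its fluorine change together. Also open, from the compounds shown here alone, are how a plain phenyl or a carboxylic acid would behave at this place, and whether the new group gives a similar step alongside the (pyrrolidin-2-yl)methyl amide of compound 1.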